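This account rests on a few compounds, and the source may have more. Where it says the series, first, only, none or still open, it means among the compounds named here.

Measured compounds in a physicochemical assay for lipophilicity, read by HPLC, at pH 7.4; on this read-out lower numbers stand for lower lipophilicity and higher numbers for higher lipophilicity:
- compound 1 `CCOC(=O)C1=C(C)N/C(=C/c2cc(C)n(-c3ccc(Cl)cc3)c2C)C1=O`: 3.4
- compound 2 `CCOC(=O)C1=C(C)N/C(=C/c2cc(C)n(-c3ccc(OC)cc3)c2C)C1=O`: 3
- compound 3 `CCOC(=O)C1=C(C)N/C(=C/c2cc(C)n(-c3ccc([S+](C)[O-])cc3)c2C)C1=O`: "not determined" (no result reported)

Compound 1 stands highest of the two numbers available in this assay; the nearest is compound 2, with a number 0.40 log units lower from compound 1 to compound 2 (beyond the scatter). Compound 3 has no number in this assay, so nothing can be said of where it lies.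

The next compound is compound 4 `CCOC(=O)C1=C(C)N/C(=C/c2cc(C)n(-c3cccnc3)c2C)C1=O`. Relative to compound 1 the change is pyridin-3-yl in place of 4-chlorophenyl on an aromatic nitrogen. For the measured compounds named here, only one measured step bears on this, and only loosely: from compound 1 to compound 2, methoxy in place of chloro on an aromatic carbon gave a number 0.40 log units lower from compound 1 to compound 2 (beyond the scatter), a modest move beyond the scatter. Going by the values given here, the change to compound 4 is larger in kind, removing chlorine and bringing in a ring nitrogen that counts as a hydrogen-bond acceptor, so a step downward in this assay clearly beyond the scatter is expected, larger than the one seen from compound 1 to compound 2. For compound 4 the estimated step is a number 1.40 log units lower from compound 1 to compound 4 (beyond the scatter). Compound 4 is thus expected to give about 2 in this assay, within the range 1.5 to 2.5.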

Compound 4, distribution coefficient: 2.1
Beside the measured number, compound 4's estimate is 0.10 log units below it; measured number inside the range.
By their numbers in this assay, from the lowest: compound 4; then compound 2; then compound 1.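

In this assay, exchanging the whole aryl group on the aromatic nitrogen moves the number further than changing only its substituent: pyridin-3-yl in place of 4-chlorophenyl gives a number 1.30 log units lower from compound 1 to compound 4 (beyond the scatter), a large step, against the modest a number 0.40 log units lower from compound 1 to compound 2 (beyond the scatter). The exchange also holds against the other aryl group, as pyridin-3-yl in place of 4-methoxyphenyl gives a number 0.90 log units lower from compound 2 to compound 4 (beyond the scatter), which leaves compound 4 lowest of the three numbers. Nothing available accounts for the size of these steps.

The compounds shown do not separate the effect of the ring nitrogen from that of losing the chloro or methoxy group, and the role of the nitrogen's place in the ring remains open. An unsubstituted phenyl, a pyridin-4-yl or a 4-aminophenyl group at this position would bear on both questions.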